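This account rests on a few compounds, and the source may have more. Where it says the series, first, only, none or still open, it means among the compounds named here.

Working notes on the series.

Two compounds of this series have a number in a functional assay on HepG2 cells (Homo sapiens) for inhibition, read by MTT assay, with a stated time of 48 h; on this read-out lower numbers stand for stronger inhibition and higher numbers for weaker inhibition. Compound 1 `COc1cccc(-n2cc(NC(=O)c3cccc(NS(=O)(=O)c4ccccc4)c3)cn2)c1` gives in this assay 25000 nM. Compound 2 `Cc1ccc(-n2cc(NC(=O)c3cccc(NS(=O)(=O)c4ccc(Cl)cc4)c3)cn2)cc1` gives in this assay 2440 nM, the lowest of the two numbers shown; the nearest number is that of compound 1, which is higher by a gap beyond the scatter. The two compounds differ in more than one place, so nothing can be said about which part of the difference carries that gap.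

Compound 3 `COc1cccc(-n2cc(NC(=O)c3cccc(NS(=O)(=O)c4ccc(Cl)cc4)c3)cn2)c1` is not yet measured in this assay. Against compound 2 the change is 3-methoxyphenyl in place of 4-methylphenyl on an aromatic nitrogen. Compound 3 thus carries the 3-methoxyphenyl of compound 1 together with the 4-chlorophenyl sulfonyl part of compound 2. Among the compounds with values here, no single-point step between measured compounds exists to set the size of this change. The expectation for compound 3 is a weakening step a 2.9-fold higher number from compound 2 to compound 3 (0.46 log units; beyond the scatter), of moderate size, because compound 1 with the same 3-methoxyphenyl gives 25000 nM while compound 2 gives 2440 nM. For compound 3 the estimate in this assay is 7000 nM, within a range from 2000 nM to 25000 nM.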

Compound 3, half-maximal inhibitory concentration: 19600 nM
For compound 3 the middle estimate is 2.8-fold (0.45 log units) below the measured one; the measured number falls inside the stated range.
By their numbers in this assay, from the lowest: compound 2; then compounds 3 and 1 (each within the scatter of the next).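

In this assay, within the data shown here, 3-methoxyphenyl in place of 4-methylphenyl on the aromatic nitrogen gives an 8.0-fold higher number from compound 2 to compound 3 (0.90 log units; beyond the scatter) with the 4-chlorophenyl sulfonyl part held fixed, the first single-point reading at this position. Here the step points to a clear preference for 4-methylphenyl over 3-methoxyphenyl, in this pair only. Chloro in place of hydrogen on an aromatic carbon, with 3-methoxyphenyl held fixed, gives a 1.3-fold lower number from compound 1 to compound 3 (0.11 log units; within the scatter) and lies within the scatter, so of the two single changes now readable, only the one on the aromatic nitrogen lies beyond it.

Going by these compounds, the change on the nitrogen alters the substituent and its place on the phenyl ring together, so 3-methylphenyl or 4-methoxyphenyl would be needed to separate the two, and it remains open how an amine or a carboxylic acid on that phenyl would read and whether chloro stays as silent alongside 4-methylphenyl. Among these compounds, no measurement on these compounds speaks to the origin of the step on the nitrogen.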